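Fluoro for methoxy on a shared thioether core

The compounds below may be only part of what the source reports. "The series", "measured", "known", "first", "only" and "open" are said of these compounds alone.

Three measured compounds share one core. Compound 1 `COc1ccc(CNc2nc3cc(N)cc(N)c3nc2-c2ccccc2)cc1OC` gives 38900 nM in a functional assay on U-251 cells (Homo sapiens) for inhibition, read by sulforhodamine B assay, with a stated time of 48 h; a higher number here means a weaker inhibitor of growth, a lower number a stronger inhibitor of growth. Compound 2 `CCOC(=O)[C@H](CCC(=O)O)NC(=O)c1ccc(Sc2nc3cc(N)cc(N)c3nc2-c2ccccc2)cc1` reaches only a limit of this assay, < 100000 nM. Compound 3 `COc1ccc(Sc2nc3cc(N)cc(N)c3nc2-c2ccccc2)cc1` likewise reaches only a limit of this assay, < 100000 nM, so no number is known for it. That limit is described by the limit of < 100000 nM in this assay, at which 2 of the 3 values shown sit. Compound 4 `Nc1cc(N)c2nc(-c3ccccc3)c(Sc3ccc(F)cc3)nc2c1` differs from compound 3 by fluoro in place of methoxy on an aromatic carbon. Within the data shown here, no measured pair shows this change, so its size and direction cannot be read from the data. The step that the limit leaves unreadable from compound 3 to compound 4 is expected to stay within the usual scatter. Compound 4 is therefore estimated at 60000 nM, with a range from 15000 nM to 150000 nM.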

Compound 4, concentration for total growth inhibition: 31600 nM
Estimate against measurement, compound 4: 1.9-fold (0.28 log units) above, and the stated range covers the measured number.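

No step can be read from compound 3 to compound 4, because compound 3 has only a limit and not a number: the limit of < 100000 nM in this assay, at which 2 of the 4 values shown sit.

Going by these compounds, what fluoro in place of methoxy on an aromatic carbon does in this assay stays open.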